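Cytotoxicity notes: cyclopropylamino to acetamido on the shared core

The source may report more compounds than this note shows. Statements on the series, on what has been measured and on what is new or still open speak of the compounds shown alone.

Measured so far:
compound 1, `Cc1cc(C)cc(Cn2c(=O)cc(NC3CC3)n(Cc3ccccc3)c2=O)c1`: > 100000 nM
compound 2, `Cc1cc(C)cc(Cn2c(=O)cc(N=[N+]=[N-])n(CC#N)c2=O)c1`: 60000 nM

In an ADME assay on MT4 cells (Homo sapiens) for cytotoxicity, read by MTT assay, with a stated time of 4 days (a lower number here means that less compound is tolerated, a higher number that more compound is tolerated), compound 1 reports only a limit, > 100000 nM, and no number; this is the limit of > 100000 nM in this assay, at which 1 of the 2 values shown sits. Compound 2 gives 60000 nM in this assay. Compound 3 `CC(=O)Nc1cc(=O)n(Cc2cc(C)cc(C)c2)c(=O)n1Cc1ccccc1` differs from compound 1 by acetyl in place of cyclopropyl on a nitrogen on an aromatic ring, read one bond further out as cyclopropylamino to acetamido. For the measured compounds named here, no step between measured compounds is available as a guide, so the expected step that the limit leaves unreadable from compound 1 to compound 3 is none beyond the scatter. Compound 3 is estimated at 150000 nM, range 50000 nM to 400000 nM.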

Compound 3, half-maximal cytotoxic concentration: > 100000 nM
Compound 3 ended at the assay's limit; the forecaster's own chance of this, stated with the estimate: 70%; the middle value does not contradict the limit.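

No step can be read from compound 1 to compound 3 in this assay, because each gives a limit and not a number: the limit of > 100000 nM in this assay, at which 2 of the 3 values shown sit.

The compounds shown leave open whether cyclopropylamino and acetamido differ at all in half-maximal cytotoxic concentration.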